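Swapping a Cyanophenyl for a Methoxyphenyl on a Weak Core

The source may report more compounds than this note shows. Statements on the series, on what has been measured and on what is new or still open speak of the compounds shown alone.

Three measured compounds share one core and differ only in the phenyl that hangs from the five-membered aromatic ring with one nitrogen and one oxygen. Compound 1 `O=[N+]([O-])c1ccc(CN2CCC(n3cc(CC(OCc4cc(-c5ccccc5)no4)c4ccc(Br)cc4)nn3)CC2)cc1` carries a plain phenyl there; in a functional assay on MDA-MB-231 cells (Homo sapiens) for cytotoxicity, with a stated time of 48 h (a higher number here means a weaker inhibitor, a lower number a stronger inhibitor), compound 1 gives > 25000 nM, which is a limit of the assay rather than a number. Compound 2 `O=[N+]([O-])c1ccc(CN2CCC(n3cc(CC(OCc4cc(-c5cccc(F)c5)no4)c4ccc(Br)cc4)nn3)CC2)cc1` carries a fluoro on that phenyl, and in this assay compound 2 gives 5000 nM. Compound 3 `N#Cc1cccc(-c2cc(COC(Cc3cn(C4CCN(Cc5ccc([N+](=O)[O-])cc5)CC4)nn3)c3ccc(Br)cc3)on2)c1` carries a cyano instead; in this assay compound 3 gives > 25000 nM, again a limit. Accordingly an at least 5.0-fold lower number from compound 1 to compound 2 (0.69 log units; beyond the scatter), whereas an at least 5.0-fold higher number from compound 2 to compound 3 (0.69 log units; beyond the scatter), and a step that the two limits leave unreadable from compound 1 to compound 3. Compound 3 therefore sits at the limit of > 25000 nM in this assay, at which 2 of the 3 values shown sit, together with compound 1. Compound 4 `COc1ccccc1-c1cc(COC(Cc2cn(C3CCN(Cc4ccc([N+](=O)[O-])cc4)CC3)nn2)c2ccc(Br)cc2)on1` brings the next change: 2-methoxyphenyl in place of 3-cyanophenyl on an aromatic carbon. Going by the values given here, none of the measured steps made this same exchange; the two readable ones only show that a single small group on this phenyl can move the number by at least a modest amount in either direction, and the weak end of that range is a limit. Compound 4 is therefore expected to remain weak, with an at least 1.3-fold lower number from compound 3 to compound 4 (0.14 log units; that floor lies within the scatter) as the expected step. The estimate for compound 4 in this assay is 18000 nM, between 4000 nM and 60000 nM.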

Compound 4, half-maximal inhibitory concentration: > 25000 nM
Compound 4 gave a limit, no number; the forecaster's own chance of this, stated with the estimate: 50%; at least 1.3-fold (0.14 log units) between middle value and limit.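

This result turns a single exception into a clearer picture: among the compounds shown, only the 3-fluorophenyl of compound 2 gives a number in this assay, while the plain phenyl, the 3-cyanophenyl and now the 2-methoxyphenyl all give limits. Exchanging the 3-fluorophenyl for the 2-methoxyphenyl gives an at least 5.0-fold higher number from compound 2 to compound 4 (0.69 log units; beyond the scatter), so a second substituted phenyl fails to keep the activity seen with fluoro, and adding any group to this phenyl is clearly not enough on its own. The steps that link compound 1, compound 3 and compound 4 to one another cannot be read, as each has a limit at both ends, and these three compounds cannot be put in order; they share one ceiling: the limit of > 25000 nM in this assay, at which 3 of the 4 values shown sit.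

Compound 2 differs from compound 4 in both the group and its place on the phenyl, so the compounds shown do not separate these two changes, and a methoxy or a fluoro moved to another place on this phenyl could do so. On these data alone, how an amine or a carboxylic acid on this phenyl would read in this assay also stays open.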